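Cytotoxicity notes: aryl substituent variation on the shared core

The compounds below may be only part of what the source reports. "The series", "measured", "known", "first", "only" and "open" are said of these compounds alone.

Compound 1 `Fc1ccc(Oc2ccc3c(NCCCNCc4ccco4)ccnc3c2)cc1` and compound 2 `Fc1ccc(Cc2ccc3c(NCCCNCc4ccco4)ccnc3c2)cc1` share one core and differ only in the group on its aromatic carbon. Among the compounds with values here, in an ADME assay on HepG2 cells (Homo sapiens) for cytotoxicity, read by luminescence, CellTiter-Glo and ATP content, with a stated time of 72 h (a higher number here means that more compound is needed for the effect, a lower number that less compound is needed), compound 1 gives 16000 nM, while compound 2 gives 5600 nM, the lower of the two numbers measured so far; the step of a 2.9-fold lower number from compound 1 to compound 2 (0.46 log units; beyond the scatter) is beyond the scatter. Compound 3 `COc1ccc(-c2ccc3c(NCCCNCc4ccco4)ccnc3c2)cc1` is not yet measured in this assay. The change from compound 2 is 4-methoxyphenyl in place of 4-fluorobenzyl on an aromatic carbon. Within the data shown here, no measured step covers this exchange: the only step, from compound 1 to compound 2, replaced one linked aryl group by another and moved the number modestly. With nothing bearing directly on a methoxyphenyl group at this position, no step beyond the scatter is expected, so compound 3 is estimated at 7000 nM (range 2500 nM to 20000 nM). The expected step of a 1.3-fold higher number from compound 2 to compound 3 (0.10 log units; within the scatter) therefore stays within the usual scatter.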

Compound 3, half-maximal effective concentration: 6000 nM
For compound 3 the middle estimate is 1.2-fold (0.07 log units) above the measured one; the range from low to high includes it.
By their numbers in this assay, from the lowest: compounds 2 and 3 (each within the scatter of the next); then compound 1.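

In this assay, 4-methoxyphenyl in place of 4-fluorobenzyl on this aromatic carbon gives a 1.1-fold higher number from compound 2 to compound 3 (0.03 log units; within the scatter), although the entering group carries 1 hydrogen-bond acceptor and the leaving group carries 0. In place of 4-fluorophenoxy, the same group gives a 2.7-fold lower number from compound 1 to compound 3 (0.43 log units; beyond the scatter), close in size to a 2.9-fold lower number from compound 1 to compound 2 (0.46 log units; beyond the scatter), so among these three compounds only compound 1 stands apart from the others. No measured evidence at hand accounts for this grouping.

The exchange in compound 3 alters the link to the aryl ring and the group on that ring together, and a 4-fluorophenyl group would be needed to separate the two. Going by these compounds, whether an amine, a carboxylic acid or a longer chain at this position would take the number outside the span of these three compounds remains open.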